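The source may report more compounds than this note shows. Statements on the series, on what has been measured and on what is new or still open speak of the compounds shown alone.

Working notes on the series. Compound 1 `CCN1CCN(CCCn2cnc3c(N4CCN(CC)CC4)nc(N4CCCC4)nc32)CC1` carries a pyrrolidin-1-yl on the aromatic carbon of the shared core; in an assay on HEK293 cells for antagonist activity at Toll-like receptor 9 (Homo sapiens), read by spectrophotometry (on this read-out lower numbers stand for stronger inhibition and higher numbers for weaker inhibition), compound 1 gives 500 nM. Compound 2 `CCN1CCN(CCCn2cnc3c(N4CCN(CC)CC4)nc(NCc4ccc(N(CC)CC)cc4)nc32)CC1` carries a 4-(diethylamino)benzyl on the ring nitrogen at that position, and in this assay compound 2 gives 440 nM. Compound 3 `CCN1CCN(CCCn2cnc3c(N4CCN(CC)CC4)nc(NC(=O)c4ccccc4)nc32)CC1` carries a benzamido group there, and in this assay compound 3 gives 340 nM. Compound 3 holds the lowest of the three numbers, yet neither neighbour is separated from it beyond the scatter: a 1.5-fold lower number from compound 1 to compound 3 (0.17 log units; within the scatter) and a 1.3-fold lower number from compound 2 to compound 3 (0.11 log units; within the scatter). The three compounds are thus not distinguished from one another in this assay.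

Compound 4 `CCN1CCN(CCCn2cnc3c(N4CCN(CC)CC4)nc(NCc4ccc(OC)cc4)nc32)CC1` is reached from compound 3 by 4-methoxybenzyl in place of benzoyl on a nitrogen on an aromatic ring. The measured step that bears on this change is the exchange of a benzyl substituent for the benzoyl on the same nitrogen, a 1.3-fold lower number from compound 2 to compound 3 (0.11 log units; within the scatter), which stayed within the scatter. Within the data shown here, compound 4 again carries a benzyl substituent on that nitrogen, as compound 2 does, and nothing measured so far has moved the number beyond the scatter. The expected step in this assay is accordingly small, a 1.3-fold higher number from compound 3 to compound 4 (0.12 log units; within the scatter), with no direction claimed beyond the scatter. The estimate for compound 4 in this assay is 450 nM, with a range from 200 nM to 1000 nM.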

Compound 4, half-maximal inhibitory concentration: 200 nM
For compound 4 the middle estimate is 2.3-fold (0.35 log units) above the measured one; the measured number falls inside the stated range.
By their numbers in this assay, from the lowest: compounds 4, 3, 2 and 1 (each within the scatter of the next, the first and the last beyond it).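

In this assay, the exchange at this nitrogen, a 1.7-fold lower number from compound 3 to compound 4 (0.23 log units; within the scatter), does not separate the two compounds, so the carbonyl of the benzamido group is not shown to be required for a number in this range. The earlier compounds shown here gave no step beyond the scatter, but two now appear, both modest: methoxy in place of diethylamino on an aromatic carbon, a 2.2-fold lower number from compound 2 to compound 4 (0.34 log units; beyond the scatter), and the exchange of pyrrolidin-1-yl for (4-methoxybenzyl)amino, a 2.5-fold lower number from compound 1 to compound 4 (0.40 log units; beyond the scatter). No evidence on hand accounts for either step.

The compounds shown leave open whether the step from compound 2 reflects the presence of methoxy or only the absence of diethylamino, a question that an unsubstituted benzyl, a 4-hydroxybenzyl or a 4-chlorobenzyl on the same nitrogen would bear on. They also leave open whether methoxy and the carbonyl act independently, which a 4-methoxybenzoyl on that nitrogen would test, and all four compounds keep the rest of the shared structure unchanged, so nothing here speaks to other parts of the molecule.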